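This account rests on a few compounds, and the source may have more. Where it says the series, first, only, none or still open, it means among the compounds named here.

Compound 1 `COc1ccc(-c2nn3cc(Cl)ccc3c2Cc2cccc(C(=O)O)n2)cc1` carries a 4-methoxyphenyl group on the shared core, and in a functional assay on cells for antagonist activity at prostaglandin E2 receptor EP1 subtype (Rattus norvegicus), read by fluorescence and calcium flux, with a stated time of 60 s (on this read-out lower numbers stand for stronger inhibition and higher numbers for weaker inhibition), compound 1 gives 5400 nM, the highest of the three numbers measured. Compound 2 `O=C(O)c1cccc(Cc2c(-c3cccs3)nn3cc(Cl)ccc23)n1` gives 1100 nM and compound 3 `O=C(O)c1cccc(Cc2c(C3CCCCC3)nn3cc(Cl)ccc23)n1` gives 1200 nM; the steps of a 4.9-fold lower number from compound 1 to compound 2 (0.69 log units; beyond the scatter) and a 4.5-fold lower number from compound 1 to compound 3 (0.65 log units; beyond the scatter) both lie beyond the scatter, while the step of a 1.1-fold higher number from compound 2 to compound 3 (0.04 log units; within the scatter) does not. Compound 4 `O=C(O)c1cccc(Cc2c(N3CCCCCC3)nn3cc(Cl)ccc23)n1` differs from compound 1 by azepan-1-yl in place of 4-methoxyphenyl on an aromatic carbon. Both recorded replacements of the 4-methoxyphenyl group lowered the number by a modest amount, and azepan-1-yl, a seven-membered non-aromatic ring, is expected to give a comparable shift, so compound 4 is expected to show a step of a 3.6-fold lower number from compound 1 to compound 4 (0.56 log units; beyond the scatter). Compound 4 is therefore estimated at 1500 nM, within 500 nM to 5000 nM.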

Compound 4, half-maximal inhibitory concentration: 1400 nM
The estimate for compound 4 lay 1.1-fold (0.03 log units) above the measured number, within the range that was stated.
By their numbers in this assay, from the lowest: compounds 2, 3 and 4 (each within the scatter of the next); then compound 1.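

In this assay, within the data shown here, azepan-1-yl, the only group here joined to the aromatic carbon through a ring nitrogen, still brings a 3.9-fold lower number from compound 1 to compound 4 (0.59 log units; beyond the scatter), and it stands level with the other two replacements, with a 1.2-fold higher number from compound 3 to compound 4 (0.07 log units; within the scatter) and a 1.3-fold higher number from compound 2 to compound 4 (0.10 log units; within the scatter). At this position thiophen-2-yl, cyclohexyl and azepan-1-yl thus give matching numbers despite their different rings, and only the 4-methoxyphenyl of compound 1 stands apart. Nothing available explains this. Going by these compounds, whether diethylamino, an open-chain amine, or unsubstituted phenyl would match these three or depart from them remains open.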